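The source may report more compounds than this note shows. Statements on the series, on what has been measured and on what is new or still open speak of the compounds shown alone.

In a functional assay on the whole organism for antagonist activity, with Mus musculus as the target (a lower number here means that less compound is needed, a higher number that more compound is needed for the effect), compound 1 `Cc1cncn1CC#CCN1C(=O)CCC1C` gives 0.8 mg/kg, while compound 3 `COC(=O)NCC#CCn1cncc1C` gives 66 mg/kg. Compound 2 `CC(=O)N(C)CC#CCN(C)C` stands at > 10 mg/kg in this assay, and this is a limit of the assay, not a number. It therefore fixes no exact starting point for the next step.

Compound 4 `COC(=O)N(C)CC#CCN(C)C` differs from compound 2 in one place: methoxy in place of methyl on a carbonyl carbon. In words, methoxy stands in place of methyl on a carbonyl carbon, which turns acetyl into methoxycarbonyl. Within the data shown here, no measured pair shows this change, so any expectation rests on thin ground. The closest guide is compound 3, which also carries methoxycarbonyl and gives 66 mg/kg, although it differs from compound 4 elsewhere. A high dose is therefore expected for compound 4, and the result may again be only a limit. The expected change is a step that the limit leaves unreadable from compound 2 to compound 4, estimated as small and of uncertain direction. For compound 4 the estimated value in this assay is 30 mg/kg, with an expected range from 8 mg/kg to 100 mg/kg.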

Compound 4, dose for half-maximal effect: > 30 mg/kg
Compound 4: a limit, no number; the forecaster's own chance of this, stated with the estimate: 50%; the middle value sits exactly at the limit.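

In this assay compound 2 stands at > 10 mg/kg, which is a limit and not a number. Compound 4 stands at > 30 mg/kg, also a limit, and no step can be read between compound 2 and compound 4. The compounds shown leave open what methoxy in place of methyl on a carbonyl carbon does to the dose in this assay.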